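A few compounds are considered here, and "the series" means these few. Any claim that something is new, unique, unknown or untested is made for them only; others in the source may bear on it.

Compound 1 `O=C(/C=C/c1ccc(F)cc1)Oc1ccc(/C=C2\CCCCC2=O)cc1`: 30900 nM
Compound 2 `CN(C)CC1CCC/C(=C\c2ccc(OC(=O)/C=C/c3ccc(F)cc3)cc2)C1=O`: 1840 nM
Compound 3 `Cc1ccc(C(=O)Oc2ccc(/C=C3\CCCCC3=O)cc2)cc1`: 44800 nM

All three numbers come from a functional assay on L1210 cells (Mus musculus); on this read-out lower numbers stand for stronger inhibition and higher numbers for weaker inhibition. Compound 2 has the lowest number of the three, and its gap to each of the others lies beyond the usual scatter.

Compound 4 `COc1ccc(C(=O)Oc2ccc(/C=C3\CCCC(CN(C)C)C3=O)cc2)cc1` has not been measured yet. It keeps the (dimethylamino)methyl group of compound 2, but the group on the carbonyl carbon changes: 4-methoxyphenyl in place of 2-(4-fluorophenyl)ethenyl on a carbonyl carbon.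

Within the data shown here, the only measured step between compounds differing in one place is large: a 17-fold lower number from compound 1 to compound 2 (1.23 log units; beyond the scatter). It concerns the arrival of (dimethylamino)methyl, though, and compound 2 and compound 4 both carry that group, so it does not speak directly to this swap. A closer guide is a pair that lacks the group and differs on the carbonyl carbon: compound 1 at 30900 nM and compound 3 at 44800 nM. These two values lie within the scatter of each other. Among the measured compounds shown here, no measured pair tests such a swap with (dimethylamino)methyl present, so this guide is indirect.

In this assay, no change beyond the scatter is therefore expected. The expected size of the change is a 1.3-fold higher number from compound 2 to compound 4 (0.12 log units; within the scatter). The estimate for compound 4 is 2400 nM, with an expected range from 900 nM to 6500 nM.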

Compound 4, half-maximal inhibitory concentration: 2870 nM
Beside the measured number, compound 4's estimate is 1.2-fold (0.08 log units) below it; the measured number falls inside the stated range.
By their numbers in this assay, from the lowest: compounds 2 and 4 (each within the scatter of the next); then compounds 1 and 3 (each within the scatter of the next).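

In this assay, replacing 2-(4-fluorophenyl)ethenyl with 4-methoxyphenyl on a carbonyl carbon gives a 1.6-fold higher number from compound 2 to compound 4 (0.19 log units; within the scatter) with the (dimethylamino)methyl group in place on both compounds, so the swap has now been tested directly in its presence. The step stays within the scatter, even though the two groups differ in what is counted for them: the group that leaves has a double bond outside aromatic rings and a fluorine, while the group that enters has an oxygen and a hydrogen-bond acceptor. In this one pair, then, those differences do not separate the two numbers, and no other measurement shown here offers an explanation for that.

The compounds shown leave open whether this tolerance extends to groups of another kind on the same carbonyl carbon, such as a 4-aminophenyl group, a 4-carboxyphenyl group or a longer open chain with no ring. Among these compounds, they also leave open how a compound carrying 4-methoxyphenyl but lacking (dimethylamino)methyl would read, so the effect of adding that group has been measured with only one group on the carbonyl carbon.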